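One Ring Enlargement, Tried Again on a Second Core

The source may hold more compounds than are shown below. What is called first, only, known or untested is meant among the compounds shown, and "the series" means these compounds.

Of the compounds shown here, three have been measured in a functional assay on A549 cells (Homo sapiens) for antiproliferative activity, read by MTT assay, with a stated time of 72 h (a lower number here means a stronger inhibitor, a higher number a weaker inhibitor), and a fourth awaits its number. Compound 1 `CCC/C=C/C(=O)Nc1cc2c(N3CCc4ccccc43)ncnc2cc1O[C@@H]1CCOC1` gives 9110 nM in this assay. Compound 2 `CCC/C=C/C(=O)Nc1cc2c(N3CCCc4ccccc43)ncnc2cc1O[C@@H]1CCOC1` differs from it in one place, (1,2,3,4-tetrahydroquinolin-1-yl in place of 2,3-dihydro-1H-indol-1-yl on an aromatic carbon), and in this assay compound 2 gives 7320 nM. That change made a 1.2-fold lower number from compound 1 to compound 2 (0.10 log units; within the scatter), so the two numbers cannot be told apart.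

Compound 3 `COc1cc2ncnc(N3CCc4ccccc43)c2cc1NC(=O)/C=C/CN(C)C` is built on another core; the difference between the two cores is not broken down here. In this assay compound 3 gives 2040 nM, the lowest of the three numbers, and its distance from both compound 1 and compound 2 lies beyond the scatter.

Compound 4 `COc1cc2ncnc(N3CCCc4ccccc43)c2cc1NC(=O)/C=C/CN(C)C` is the one not yet measured. It differs from compound 3 by 1,2,3,4-tetrahydroquinolin-1-yl in place of 2,3-dihydro-1H-indol-1-yl on an aromatic carbon. Within the data shown here, this is the same change as the one from compound 1 to compound 2, at the same place on the core, and it occurs twice among the four compounds. Because the earlier instance gave a 1.2-fold lower number from compound 1 to compound 2 (0.10 log units; within the scatter), the step is expected to be small again, estimated as a 1.2-fold lower number from compound 3 to compound 4 (0.08 log units; within the scatter). Compound 4 is therefore expected near 1700 nM, with the estimate spanning 700 nM to 4500 nM. This rests on a single earlier instance of the change, made on a different core, so the range is kept wide.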

Compound 4, half-maximal inhibitory concentration: 1650 nM
For compound 4 the middle estimate is 1.0-fold (0.01 log units) above the measured one; the measured number falls inside the stated range.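

In this assay, putting 1,2,3,4-tetrahydroquinolin-1-yl in place of 2,3-dihydro-1H-indol-1-yl on the core of compound 3 gave a 1.2-fold lower number from compound 3 to compound 4 (0.09 log units; within the scatter), so the two numbers cannot be told apart. The change therefore carried over from one core to the other with no detectable difference in its size, as the two instances show: the same change on two cores in this assay, a 1.2-fold lower number (0.10 log units; within the scatter) from compound 1 to compound 2 and a 1.2-fold lower number (0.09 log units; within the scatter) from compound 3 to compound 4, 1.0-fold (0.00 log units) apart, within the scatter of two such steps. Among these compounds, this shows only that the change stays within the scatter on these two cores in this one cellular read-out; with two instances it cannot establish a general rule for the series, and steps this small say nothing about why the change matters so little.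

The compounds shown leave open how much of the gap between compound 3 and the pair of compound 1 and compound 2 belongs to each part in which their cores differ, such as the methoxy group, the tetrahydrofuranyloxy group or the dimethylamino group on the amide chain. They also leave open whether the same replacement would stay as small with a morpholine at the end of that chain, or whether a fluorine or a methoxy on the six-membered aromatic ring of carbon only would alter the picture.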